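Bromo for Methyl on the Aryl Ring of Compound 1

The source may report more compounds than this note shows. Statements on the series, on what has been measured and on what is new or still open speak of the compounds shown alone.

Measured compounds:
compound 1 `Cc1ccc(C2=NN(C3=NC(=O)CS3)C(c3ccc4ccccc4c3)C2)cc1`, 1760 nM
compound 2 `Fc1ccc(C2=NN(C3=NC(c4ccccc4)CS3)C(c3cccc4ccccc34)C2)cc1`, 12400 nM
compound 3 `O=C1CSC(N2N=C(c3ccc(Br)cc3)CC2c2cccc3ccccc23)=N1`, 5810 nM

In a functional assay on HeLa cells (Homo sapiens) for inhibition, read by CCK-8 assay, with a stated time of 48 h (a lower number here means a stronger inhibitor, a higher number a weaker inhibitor), compound 1 gives 1760 nM, the lowest number of the three. Compound 3 gives 5810 nM, which lies beyond the scatter above compound 1, and compound 2 gives 12400 nM, further away still. Among the measured compounds shown here, no two of the measured compounds differ in a single place, so no step between them can be counted.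

Compound 4 `O=C1CSC(N2N=C(c3ccc(Br)cc3)CC2c2ccc3ccccc3c2)=N1` differs from compound 1 in one place: bromo in place of methyl on an aromatic carbon. The nearest measured point of reference is compound 3, which also carries bromo on a 4-bromophenyl group but differs from compound 4 elsewhere; the value of compound 3, 5810 nM, can only hint at what this change does. Without a counted step, compound 4 is expected to lie somewhat above compound 1 in this assay, a step of a 1.7-fold higher number from compound 1 to compound 4 (0.23 log units; within the scatter), modest and near the edge of the scatter. Compound 4 is therefore estimated at 3000 nM, with a range from 1200 nM to 8000 nM.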

Compound 4, half-maximal inhibitory concentration: 4220 nM
For compound 4 the middle estimate is 1.4-fold (0.15 log units) below the measured one; measured number inside the range.
By their numbers in this assay, from the lowest: compound 1; then compounds 4 and 3 (each within the scatter of the next); then compound 2.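

In this assay, among the compounds shown here, the change from 4-methylphenyl to 4-bromophenyl gives the first step that can be counted, a 2.4-fold higher number from compound 1 to compound 4 (0.38 log units; beyond the scatter) and so beyond the scatter, though modest. The position para to a large group therefore responds to a change of a single heavy atom, even though no ring, hydrogen-bond donor, hydrogen-bond acceptor or charge enters or leaves, and on this core methyl gives the lower number of the two groups. Nothing available here accounts for the size or direction of this step.

The compounds shown leave open how an amine, a methoxy group or a chloro group would read at this same place. They also leave open whether the step holds on other cores, since compound 2 and compound 3 have no 4-methylphenyl partner here.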